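One More Carbon on a Charged Oxime Series

A few compounds are considered here, and "the series" means these few. Any claim that something is new, unique, unknown or untested is made for them only; others in the source may bear on it.

Measured so far:
Compound 1, `CC[n+]1ccn(CCN(C)C)c1/C=N/O`, gives -2.71 in a physicochemical assay for lipophilicity; a lower number here means a more polar compound, a higher number a more lipophilic compound.
Compound 2, `CCC[n+]1ccn(CCN(C)C)c1/C=N/O`, gives -2.73 in this assay.
Compound 3, `CN(CCCn1cc[n+](C)c1/C=N/O)S(=O)(=O)c1ccccc1`, gives -1.59 in this assay.

Compound 3 stands highest of the three; its nearest neighbour is compound 1, and the difference between the two cores is not broken down here. Compounds 1 and 2 differ by methyl in place of hydrogen on a saturated chain carbon, two bonds along the chain from an aromatic nitrogen, and this step gave a number 0.02 log units lower from compound 1 to compound 2 (within the scatter).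

Compound 4, `CCN(CCCn1cc[n+](C)c1/C=N/O)S(=O)(=O)c1ccccc1`, is not yet measured. It differs from compound 3 by methyl in place of hydrogen on a saturated chain carbon bound to a sulfonamide nitrogen. This is the same kind of change as that from compound 1 to compound 2, but the place differs: there the carbon was two bonds along the chain from an aromatic nitrogen, here it is bound to a sulfonamide nitrogen. Because the earlier step gave a number 0.02 log units lower from compound 1 to compound 2 (within the scatter), a small step is expected here too, a number 0.14 log units higher from compound 3 to compound 4 (within the scatter), so compound 4 is estimated at -1.45 in this assay, with a likely range from -1.9 to -1.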

Compound 4, distribution coefficient: -1.27
Beside the measured number, compound 4's estimate is 0.18 log units below it, and the stated range covers the measured number.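

In this assay, methyl in place of hydrogen gave a number 0.32 log units higher from compound 3 to compound 4 (beyond the scatter) on this core, while the same kind of change on the other core gave a number 0.02 log units lower from compound 1 to compound 2 (within the scatter), so the size of the step did not carry over unchanged from one core to the other. This does not show that the core alone sets the size of the step, since the place changes with the core, from a carbon two bonds along the chain from an aromatic nitrogen to a carbon bound to a sulfonamide nitrogen, and each case rests on a single pair of compounds. The compounds shown offer no measured explanation for why the two steps came out as they did.

As far as these compounds go, whether a longer chain, such as propyl, bound to the sulfonamide nitrogen would extend the step seen with ethyl remains open. So does what a carboxylic acid or an amine at the end of that chain would do to the number.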